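The source may hold more compounds than are shown below. What is called first, only, known or untested is meant among the compounds shown, and "the series" means these compounds.

In a functional assay on PC-3 cells (Homo sapiens) for inhibition, read by MTT assay, with a stated time of 48 h, tested at 10 uM (a higher number here means more inhibition of growth at the concentration tested, a lower number less inhibition of growth), compound 2 `Cc1oc2c([C@H]3CCN(C)C[C@H]3O)c(O)cc(O)c2c(=O)c1C(O)c1ccc([N+](=O)[O-])cc1` gives 24%. Within the data shown here, compound 1 `Cc1cc(=O)c2c(O)cc(OCc3ccc([N+](=O)[O-])cc3)c([C@H]3CCN(C)C[C@H]3O)c2o1`, the only other compound measured here, gives 23%, and the two numbers lie within the usual scatter of each other, so neither can be set above the other. Compound 3 `Cc1oc2c([C@H]3CCN(C)C[C@H]3O)c(O)cc(O)c2c(=O)c1C(O)c1cccc(Cl)c1Cl` is not yet measured. It differs from compound 2 in a single place: 2,3-dichlorophenyl in place of 4-nitrophenyl on a saturated chain carbon bound to an aromatic carbon and an oxygen on a saturated carbon. Among the measured compounds shown here, no step between measured compounds shows how such a swap plays out, so the expected step of a number 1 percentage points higher from compound 2 to compound 3 (within the scatter) is small, with no direction beyond the scatter. Compound 3 is accordingly estimated at 25%, within a range from 8% to 45%.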

Compound 3, percent growth inhibition at one concentration: 20%
Estimate against measurement, compound 3: 5 percentage points above, and the stated range covers the measured number.
By their numbers in this assay, from the lowest: compounds 3, 1 and 2 (each within the scatter of the next).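

In this assay, putting 2,3-dichlorophenyl in place of 4-nitrophenyl brings a number 4 percentage points lower from compound 2 to compound 3 (within the scatter). This first step at the saturated chain carbon therefore shows that these two aromatic groups cannot be told apart here, although the nitro group's oxygens and nitrogen give way to two chlorines. No supporting measurement bears on this result.

On these data alone, whether a simple amine or a carboxylic acid in place of 4-nitrophenyl would read differently remains open. This single step also cannot show how other substituted phenyl groups would behave at this position.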